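Swapping the ether ring for a methylpiperidinylmethyl chain

A few compounds are considered here, and "the series" means these few. Any claim that something is new, unique, unknown or untested is made for them only; others in the source may bear on it.

Measured so far:
Compound 1 `COc1ncc(-c2cc(OC3CCOCC3)c3ncnc(C)c3c2)cc1NS(=O)(=O)c1ccc(F)cc1F` gives 42 10^-6 cm/s in an ADME assay on Caco-2 cells (Homo sapiens) for permeability, read by LC-MS, in the apical to basolateral direction, with a stated time of 90 min; a lower number here means that the compound crosses the layer more slowly, a higher number that the compound crosses the layer faster.
Compound 2 `COc1ncc(-c2cc(OC3CCOC(C)(C)C3)c3ncnc(C)c3c2)cc1NS(=O)(=O)c1ccc(F)cc1F` gives 31 10^-6 cm/s in this assay.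

Compound 2 holds the lowest of the two numbers, and its nearest neighbour is compound 1; the step of a 1.4-fold lower number from compound 1 to compound 2 (0.13 log units; within the scatter) is within the scatter, so the two compounds cannot be ranked against each other.

Compound 3 `COc1ncc(-c2cc(OCC3CCN(C)CC3)c3ncnc(C)c3c2)cc1NS(=O)(=O)c1ccc(F)cc1F` differs from compound 2 in one place: (1-methylpiperidin-4-yl)methyl in place of 2,2-dimethyloxan-4-yl on an oxygen on an aromatic ring. Among the measured compounds shown here, the only measured step, a 1.4-fold lower number from compound 1 to compound 2 (0.13 log units; within the scatter), also sits on this oxygen, but it exchanged one oxygen-containing ring for another and left the number essentially unchanged. For the measured compounds named here, no measured step covers a change from an oxygen ring to a nitrogen ring on this position, so the expectation rests on the structural change alone.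

For compound 3 a lower number is expected, a step of a 3.1-fold lower number from compound 2 to compound 3 (0.49 log units; beyond the scatter), giving an estimate of 10 10^-6 cm/s with a range from 3 10^-6 cm/s to 30 10^-6 cm/s.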

Compound 3, apparent permeability: 8.8 10^-6 cm/s
Compound 3: the middle estimate sits 1.1-fold (0.06 log units) above what was measured; measured number inside the range.
By their numbers in this assay, from the lowest: compound 3; then compounds 2 and 1 (each within the scatter of the next).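

Trading one oxygen-containing ring for another on this oxygen left the number within the scatter, but the nitrogen ring behaves differently in this assay: (1-methylpiperidin-4-yl)methyl in place of 2,2-dimethyloxan-4-yl gives a 3.5-fold lower number from compound 2 to compound 3 (0.55 log units; beyond the scatter) and so shows that this position does respond to the group it carries. Set against oxan-4-yl, the same group gives a 4.8-fold lower number from compound 1 to compound 3 (0.68 log units; beyond the scatter) and points the same way, so both oxygen rings sit beyond the scatter from it. Nothing on hand explains this fall. The entering group differs from both oxygen rings by a ring nitrogen carrying a methyl and by an extra carbon link to the oxygen, and these compounds cannot separate the two changes. A 1-methylpiperidin-4-yl group sitting directly on the oxygen would pull them apart.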